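This account rests on a few compounds, and the source may have more. Where it says the series, first, only, none or still open, it means among the compounds named here.

- compound 1 `CCNC(=O)c1cc(Oc2ccc(NC(=O)c3nn(-c4cccc(F)c4)c(=O)cc3C)cc2)ccn1` gives 6870 nM
- compound 2 `CNC(=O)c1cc(Oc2ccc(NC(=O)c3nn(-c4ccccc4Cl)c(=O)cc3C)cc2F)ccn1` gives 9870 nM
- compound 3 `CCNC(=O)c1cc(Oc2ccc(NC(=O)c3nn(-c4ccc(C)cc4)c(=O)cc3C)cc2)ccn1` gives 10700 nM

These numbers come from a functional assay on HeLa cells (Homo sapiens) for antiproliferative activity, read by MTT assay, with a stated time of 72 h; on this read-out lower numbers stand for stronger inhibition and higher numbers for weaker inhibition. In this assay compound 2 gives 9870 nM and sits among the other two numbers, within the usual scatter of both compound 1 and compound 3, so no order can be read among the three.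

Compound 4 `CNC(=O)c1cc(Oc2ccc(NC(=O)c3nn(-c4cccc(C(F)(F)F)c4)c(=O)cc3C)cc2F)ccn1` has not yet been measured. It differs from compound 2 in one place, with 3-(trifluoromethyl)phenyl in place of 2-chlorophenyl on an aromatic nitrogen.

Within the data shown here, only one measured step swaps a group at this same kind of position, and it does so on a slightly different molecule: 4-methylphenyl in place of 3-fluorophenyl (a 1.6-fold higher number from compound 1 to compound 3 (0.19 log units; within the scatter)). That step did not leave the scatter. Among the measured compounds shown here, no measured compound carries the trifluoromethyl group, so the evidence is thin. On this single step, no change beyond the scatter is expected in either direction.

The estimate therefore means only a small expected step (a 1.2-fold lower number from compound 2 to compound 4 (0.09 log units; within the scatter)). Compound 4 is expected to give an estimated value of 8000 nM (expected range 3500 nM to 20000 nM).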

Compound 4, half-maximal inhibitory concentration: 11800 nM
Estimate against measurement, compound 4: 1.5-fold (0.17 log units) below; the measured number falls inside the stated range.
By their numbers in this assay, from the lowest: compounds 1, 2, 3 and 4 (each within the scatter of the next).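

Putting 3-(trifluoromethyl)phenyl in place of 2-chlorophenyl on the aromatic nitrogen gives a 1.2-fold higher number from compound 2 to compound 4 (0.08 log units; within the scatter) in this assay, even though the group that enters has more heavy atoms than the group that leaves. The earlier step at this kind of position, a 1.6-fold higher number from compound 1 to compound 3 (0.19 log units; within the scatter), was made on a molecule with a different amide chain, so there are now two such swaps on two different backgrounds, and neither leaves the scatter. This holds only for these four compounds, all of which carry a substituted phenyl at this position, and nothing measured here bears on the reason for the result.

The compounds shown leave open whether anything other than a phenyl with a halogen, methyl or trifluoromethyl group would give a clearly different number at this position, such as a phenyl bearing an amine or a carboxylic acid, or a longer chain in place of the phenyl. They also leave the other parts of the molecule unresolved, since no listed step separates the ethyl amide from the methyl amide or tests the extra fluorine on the core of compounds 2 and 4.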